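The compounds below may be only part of what the source reports. "The series", "measured", "known", "first", "only" and "open" are said of these compounds alone.

Compound 1 `O=C(/C(=C\c1ccccc1F)S(=O)(=O)c1ccc(Br)cc1)c1ccc(Cl)cc1` in a functional assay on DU-145 cells (Homo sapiens) for inhibition, read by trypan blue exclusion, with a stated time of 96 h (a higher number here means a weaker inhibitor of growth, a lower number a stronger inhibitor of growth), gives 25000 nM.
Compound 2 `O=C(/C(=C\c1ccccc1OCc1ccccc1)S(=O)(=O)c1ccc(Br)cc1)c1ccc(Cl)cc1` in this assay gives 1000 nM.
Compound 3 `COc1ccccc1/C=C(\C(=O)c1ccc(Cl)cc1)S(=O)(=O)c1ccc(Br)cc1` in this assay gives 10000 nM.

Compound 2 has the lowest number of the three. The benzyloxy group on its aromatic ring brings a 25-fold lower number from compound 1 to compound 2 (1.40 log units; beyond the scatter), and dropping the phenyl from that group brings a 10-fold higher number from compound 2 to compound 3 (1.00 log units; beyond the scatter), so both measured steps concern only the ring that carries the benzyloxy group.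

Compound 4 `COc1ccc(S/C(=C/c2ccccc2OCc2ccccc2)C(=O)c2ccc(Cl)cc2)cc1` keeps that ring untouched and instead alters the sulfur-bearing group: (4-methoxyphenyl)sulfanyl in place of (4-bromophenyl)sulfonyl on a double-bonded chain carbon bound to a carbonyl carbon and a double-bonded chain carbon. Going by the values given here, no measured step changes anything at this place, so none of the three steps bears directly on it, and the measured changes on the other ring give no guidance about the size or direction of this one. The expectation for compound 4 is therefore weakly founded: a modest rise in the number is expected, with a wide range, giving a 3.0-fold higher number from compound 2 to compound 4 (0.48 log units; beyond the scatter). Compound 4 is estimated at 3000 nM, expected between 500 nM and 20000 nM.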

Compound 4, concentration for 50% growth inhibition: 1000 nM
Compound 4: middle estimate off by 3.0-fold (0.48 log units), on the high side, and the stated range covers the measured number.
By their numbers in this assay, from the lowest: compounds 2 and 4 (each within the scatter of the next); then compound 3; then compound 1.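

Putting (4-methoxyphenyl)sulfanyl in place of (4-bromophenyl)sulfonyl on the double-bonded chain carbon bound to a carbonyl carbon and a double-bonded chain carbon gives no change at the digits printed from compound 2 to compound 4 (within the scatter) in this assay. Going by these compounds alone, this is the first look at this place, and it shows that, with the benzyloxy group present, growth inhibition in this pair does not depend on keeping the sulfonyl or the bromine, whereas the changes on the other ring all moved the number beyond the scatter. No supporting evidence is available to explain this result.

On these data alone, the swap alters the sulfur link and the ring substituent together, so it remains open whether each change alone is silent or the two offset each other. Also open, as far as these compounds go, is how this place responds to an amine or a carboxylic acid on that ring, or to a longer chain between the sulfur and the ring.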